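Compound 2 to compound 3: acetyl off the nitrogen

The source may hold more compounds than are shown below. What is called first, only, known or untested is meant among the compounds shown, and "the series" means these compounds.

In an ADME assay on THP-1 cells (Homo sapiens) for cytotoxicity, read by flow cytometry and propidium iodide staining, with a stated time of 72 h (on this read-out higher numbers stand for weaker inhibition and lower numbers for stronger inhibition), compound 1 (`COc1ccccc1-c1oc2ccc(NC(C)=O)cc2c(=O)c1OC`) gives 108000 nM as its value.

Compound 2 (`COc1c(-c2ccc(F)cc2)oc2ccc(NC(C)=O)cc2c1=O`) stands at > 125000 nM which is a limit of the assay and not a number.

Compound 3 (`COc1c(-c2ccc(F)cc2)oc2ccc(N)cc2c1=O`) carries hydrogen in place of acetyl on a nitrogen on an aromatic ring.

Going by the values given here, the one measured step is an at least 1.1-fold higher number from compound 1 to compound 2 (0.06 log units; that floor lies within the scatter) on an aromatic carbon, not at this nitrogen, so it offers only weak guidance. Among the compounds with values here, no step clearly beyond the scatter is therefore expected in this assay for this change.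

The expected step is an at least 1.3-fold lower number from compound 2 to compound 3 (0.14 log units; that floor lies within the scatter) with the direction uncertain.

Compound 3 is estimated at 90000 nM within a range of 30000 nM to 125000 nM on this read-out.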

Compound 3, half-maximal inhibitory concentration: 36000 nM
The estimate for compound 3 lay 2.5-fold (0.40 log units) above the measured number; low and high end bracket the measured number.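

In this assay the change from acetamido to amino on this nitrogen gives a step beyond the scatter: an at least 3.4-fold lower number from compound 2 to compound 3 (0.54 log units; beyond the scatter) and thus stronger inhibition. The change on the aromatic carbon gave no such reading, with an at least 1.1-fold higher number from compound 1 to compound 2 (0.06 log units; that floor lies within the scatter) as its step. This step is only a floor, and compound 2 stands at a limit of the assay and not a number: the limit of > 125000 nM in this assay, at which 1 of the 3 values shown sits.

Open, going by these compounds, is whether a methyl group, a longer acyl chain or a sulfonamide on this nitrogen would fall nearer compound 2 or compound 3. Also open, on these data alone, is whether the amino group would lower the number with the 2-methoxyphenyl group of compound 1 in place.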